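Toxicity notes on the shared-core amides, compound 4

A few compounds are considered here, and "the series" means these few. Any claim that something is new, unique, unknown or untested is made for them only; others in the source may bear on it.

Three compounds in the series have numbers in a toxicity assay on Huh-7.5 cells (Homo sapiens) for inhibition, read by MTT assay, with a stated time of 96 h; a lower number here means that less compound is tolerated, a higher number that more compound is tolerated. Compound 1 `CN1CCN(Cc2ccc(NC(=O)c3ccc(OCCCCl)c([N+](=O)[O-])c3)cc2C#N)CC1` gives 15500 nM. Compound 2 `CCC(=O)Nc1cc(C(=O)Nc2ccc(CN3CCN(C)CC3)c(C(F)(F)F)c2)ccc1OC` gives 35300 nM, and compound 3 `CCC(=O)Nc1cc(C(=O)Nc2ccc(CN3CCN(C)CC3)c(C(F)(F)F)c2)ccc1OCCCCl` gives 7870 nM. For the measured compounds named here, on these numbers compound 3 stands lowest: compound 1 sits within the scatter of it, while compound 2 lies beyond the scatter, the only single-point step measured so far being a 4.5-fold lower number from compound 2 to compound 3 (0.65 log units; beyond the scatter).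

Compound 4 `CN1CCN(Cc2ccc(NC(=O)c3ccc(OCCCCl)c(C(F)(F)F)c3)cc2C(F)(F)F)CC1` is not yet measured. It differs from compound 3 in one place: trifluoromethyl in place of propanoylamino on an aromatic carbon. Going by the values given here, no measured step in this assay touches this position; the one step known concerns the 3-chloropropoxy group, which compound 3 and compound 4 carry unchanged. There is therefore no basis for expecting a shift beyond the scatter in either direction, and compound 4 is expected to come out near compound 3, the estimated step being a 1.2-fold lower number from compound 3 to compound 4 (0.08 log units; within the scatter). For compound 4 the estimate in this assay is 6500 nM, with a range from 2500 nM to 17000 nM.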

Compound 4, half-maximal cytotoxic concentration: 13400 nM
The estimate for compound 4 lay 2.1-fold (0.31 log units) below the measured number, and the stated range covers the measured number.
By their numbers in this assay, from the lowest: compounds 3, 4 and 1 (each within the scatter of the next); then compound 2.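

In this assay, the place ortho to a 3-chloropropoxy group now has a measured step of its own, whereas the earlier step concerned only the ether chain: a 1.7-fold higher number from compound 3 to compound 4 (0.23 log units; within the scatter). Within the scatter, this exchange of propanoylamino for trifluoromethyl removes the amide hydrogen and carbonyl of the leaving group and leaves compound 3 and compound 4 indistinguishable in this assay. No evidence bearing on this step is available.

The compounds shown leave open whether an amine, a carboxylic acid or a longer acylamino chain at this place would also stay within the scatter of compound 3. As far as these compounds go, it is also open whether trifluoromethyl would give a similarly small step on compound 2, which carries methoxy instead of 3-chloropropoxy.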